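Trading a Methoxyethol Chain for Isopropyl on the Ether

This account rests on a few compounds, and the source may have more. Where it says the series, first, only, none or still open, it means among the compounds named here.

The measured compounds, all read in a functional assay on CHO cells for inhibition of metabotropic glutamate receptor 5 (Rattus norvegicus), read by FLIPR and calcium flux; a higher number here means a weaker inhibitor, a lower number a stronger inhibitor:

compound 1 `Cc1ccc2ccc(-c3cc(C#N)cc(C#N)c3)cc2n1` — compound 1 gives 2 nM
compound 2 `Cc1ccc2ccc(-c3cc(Br)cc(C#N)c3)cc2n1` — compound 2 gives 13 nM
compound 3 `COCCOc1cc(C#N)cc(-c2ccc3ccc(C)nc3c2)c1` — compound 3 gives 82 nM

Compound 3 carries the highest number of the three. Its nearest neighbour is compound 2, as the step of a 6.3-fold higher number from compound 2 to compound 3 (0.80 log units; beyond the scatter) shows; the furthest is compound 1, reached through a 41-fold higher number from compound 1 to compound 3 (1.61 log units; beyond the scatter). The remaining step, a 6.5-fold higher number from compound 1 to compound 2 (0.81 log units; beyond the scatter), connects the two stronger compounds.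

Compound 4 `Cc1ccc2ccc(-c3cc(C#N)cc(OC(C)C)c3)cc2n1` is the next member. It differs from compound 3 in one place: isopropyl in place of 2-methoxyethyl on an oxygen on an aromatic ring. The three measured steps all exchange the whole substituent on the aromatic carbon — cyano, bromo or 2-methoxyethoxy — and none of them alters only the chain hanging from an ether oxygen. Within the data shown here, compound 3 is the sole measured compound that bears such an ether, so no measured step speaks directly to the change in hand. Lacking any such comparison, the account expects compound 4 to stay close to compound 3, with the step of a 1.4-fold lower number from compound 3 to compound 4 (0.14 log units; within the scatter) estimated to lie within or only just beyond the scatter. On that basis compound 4 is expected to give about 60 nM in this assay, with an estimated range from 20 nM to 200 nM.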

Compound 4, half-maximal inhibitory concentration: 310 nM
For compound 4 the middle estimate is 5.2-fold (0.71 log units) below the measured one; the measured number lies above the stated range.
By their numbers in this assay, from the lowest: compound 1; then compound 2; then compound 3; then compound 4.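

In this assay, the chain on this ether oxygen matters in its own right: changing only that chain, with the ring-bound oxygen kept in place, gives a step beyond the scatter (a 3.8-fold higher number from compound 3 to compound 4 (0.58 log units; beyond the scatter)), whereas every earlier step exchanged the whole substituent on the aromatic carbon. Compound 4 also shows that the two ethers do not read alike against the other substituents, since isopropoxy in place of bromo (a 24-fold higher number from compound 2 to compound 4 (1.38 log units; beyond the scatter)) outruns 2-methoxyethoxy in place of bromo (a 6.3-fold higher number from compound 2 to compound 3 (0.80 log units; beyond the scatter)), and isopropoxy in place of cyano (a 160-fold higher number from compound 1 to compound 4 (2.19 log units; beyond the scatter)) outruns 2-methoxyethoxy in place of cyano (a 41-fold higher number from compound 1 to compound 3 (1.61 log units; beyond the scatter)), which leaves compound 4 the weakest inhibitor of the four. Nothing available beyond these numbers offers an explanation for the step from the 2-methoxyethyl to the isopropyl chain.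

The change from 2-methoxyethyl to isopropyl removes the chain's oxygen and introduces branching at once, so the compounds shown cannot say which of the two differences carries the step. From the compounds shown here alone, a straight propyl chain on the same oxygen, or a 2-methoxypropyl chain that keeps the oxygen and adds the branch, would pull these apart in this assay, and how either would read remains open.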